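The source may report more compounds than this note shows. Statements on the series, on what has been measured and on what is new or still open speak of the compounds shown alone.

Measured so far in a functional assay on Mahlavu cells (Homo sapiens) for antiproliferative activity, read by sulforhodamine B assay, with a stated time of 72 h; on this read-out higher numbers stand for weaker inhibition and lower numbers for stronger inhibition:
compound 1 `Cc1cc(C)cc(COc2ccc(-c3cc(CN4CCN(Cc5ccc(C(F)(F)F)cc5)CC4)no3)cc2)c1`, 6000 nM
compound 2 `N#Cc1cccc(COc2ccc(-c3cc(CN4CCN(Cc5ccc(C(F)(F)F)cc5)CC4)no3)cc2)c1`, 10600 nM
compound 3 `Fc1ccccc1COc1ccc(-c2cc(CN3CCN(Cc4ccc(C(F)(F)F)cc4)CC3)no2)cc1`, 3100 nM

Compound 2 stands with the highest of the three numbers in this assay; compound 1 is its nearest neighbour, with a 1.8-fold higher number from compound 1 to compound 2 (0.25 log units; within the scatter), and compound 3 lies furthest, with a 3.4-fold lower number from compound 2 to compound 3 (0.53 log units; beyond the scatter). Compound 4 `COc1cc(COc2ccc(-c3cc(CN4CCN(Cc5ccc(C(F)(F)F)cc5)CC4)no3)cc2)cc(OC)c1OC` differs from compound 2 in one place: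

3,4,5-trimethoxyphenyl in place of 3-cyanophenyl on a saturated chain carbon bound to an oxygen on an aromatic ring

Both known steps at this place, from compound 1 and to compound 3, bear on it. One stayed within the scatter and one gave a modest lower number, so the group at this place has so far shifted the number only modestly. A modest step toward a lower number is therefore expected for compound 4, as a 2.1-fold lower number from compound 2 to compound 4 (0.33 log units; beyond the scatter). Compound 4 is estimated at 5000 nM, with a range from 1500 nM to 16000 nM.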

Compound 4, half-maximal inhibitory concentration: 5800 nM
For compound 4 the middle estimate is 1.2-fold (0.06 log units) below the measured one, within the range that was stated.
By their numbers in this assay, from the lowest: compounds 3, 4, 1 and 2 (each within the scatter of the next, the first and the last beyond it).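

In this assay, 3,4,5-trimethoxyphenyl in place of the earlier groups gives a 1.8-fold lower number from compound 2 to compound 4 (0.26 log units; within the scatter) and a 1.9-fold higher number from compound 3 to compound 4 (0.27 log units; within the scatter) and a 1.0-fold lower number from compound 1 to compound 4 (0.01 log units; within the scatter). This place on a saturated chain carbon bound to an oxygen on an aromatic ring thus takes a group of 12 heavy atoms and 3 hydrogen-bond acceptors with no step beyond the scatter, so the step between compound 2 and compound 3 remains the only one that is. No measurement at hand explains this. Going by these compounds, whether an amine or a carboxylic acid on the aromatic ring of this group would give a step beyond the scatter stays open.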